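Side-chain swaps on a weakly cytotoxic bisindolylmaleimide amide

A few compounds are considered here, and "the series" means these few. Any claim that something is new, unique, unknown or untested is made for them only; others in the source may bear on it.

Compound 2 `COC(=O)[C@@H](CO)NC(=O)Cn1cc(C2=C(c3c[nH]c4ccccc34)C(=O)N(C)C2=O)c2ccccc21` gives 28900 nM in a functional assay on BGC-823 cells (Homo sapiens) for cytotoxicity, read by MTT assay, with a stated time of 24 h (a higher number here means a weaker inhibitor, a lower number a stronger inhibitor), the lower of the two numbers but within the scatter of compound 1 `COC(=O)[C@H](NC(=O)Cn1cc(C2=C(c3c[nH]c4ccccc34)C(=O)N(C)C2=O)c2ccccc21)C(C)C`, which gives 48200 nM. For the measured compounds named here, the only measured step, a 1.7-fold lower number from compound 1 to compound 2 (0.22 log units; within the scatter), was inside the scatter. Compound 3 `COC(=O)CC[C@@H](NC(=O)Cn1cc(C2=C(c3c[nH]c4ccccc34)C(=O)N(C)C2=O)c2ccccc21)C(=O)OC` carries the change ((methoxycarbonyl)methyl in place of hydroxy on a saturated chain carbon, two bonds along the chain from an amide-type nitrogen and a carbonyl carbon). Since the earlier side-chain swap did not move the number beyond the scatter, no step beyond the scatter is expected here either, and the estimated step of a 1.2-fold higher number from compound 2 to compound 3 (0.08 log units; within the scatter) is near zero. Compound 3 is thus expected to give about 35000 nM, within 12000 nM to 100000 nM.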

Compound 3, half-maximal inhibitory concentration: 25000 nM
Estimate against measurement, compound 3: 1.4-fold (0.15 log units) above; low and high end bracket the measured number.
By their numbers in this assay, from the lowest: compounds 3, 2 and 1 (each within the scatter of the next).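

In this assay, the step of a 1.2-fold lower number from compound 2 to compound 3 (0.06 log units; within the scatter) shows that (methoxycarbonyl)methyl in place of hydroxy at this saturated chain carbon leaves the number within the scatter. The same holds for 2-(methoxycarbonyl)ethyl in place of isopropyl, with the step of a 1.9-fold lower number from compound 1 to compound 3 (0.29 log units; within the scatter) still inside it. An ester-bearing side chain therefore does not separate from the hydroxymethyl or isopropyl side chains here, and nothing offered bears on this result. The compounds shown leave open whether a carboxylic acid, an amine or a longer chain at this position would move the number beyond the scatter.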